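The source may hold more compounds than are shown below. What is called first, only, known or untested is meant among the compounds shown, and "the series" means these compounds.

Values in a functional assay on BV-2 cells (Mus musculus) for inhibition, read by Griess assay, with a stated time of 10 min (a lower number here means a stronger inhibitor, a higher number a weaker inhibitor), for the measured compounds:

compound 1 `CO[C@@H](CC(=O)O[C@@]1(C(=O)O)C[C@@H](O)[C@@H](O)[C@H](OC(=O)/C=C/c2ccc(O)c(O)c2)C1)c1ccc(O)c(O)c1`: 12500 nM
compound 2 `O=C(/C=C\c1ccc(O)cc1)O[C@@H]1C[C@](OC(=O)/C=C/c2ccc(O)cc2)(C(=O)O)C[C@@H](O)[C@H]1O`: 59800 nM
compound 3 `COC(=O)[C@@]1(O)C[C@@H](O)[C@H](OC(=O)/C=C/c2ccc(O)c(O)c2)[C@H](OC(=O)/C=C/c2ccc(O)c(O)c2)C1`: 20200 nM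

Compound 3 holds the second highest of the three numbers. Compound 1 lies within the scatter of compound 3, so the two are not separated in this assay; compound 2 gives a higher number than compound 3, beyond the scatter.

Compound 4 `COC(=O)[C@]1(O)C[C@@H](O)[C@@H](OC(=O)/C=C/c2ccc(O)c(O)c2)[C@H](O)C1` differs from compound 3 in one place: hydrogen in place of (2-(3,4-dihydroxyphenyl)ethenyl)carbonyl on an oxygen on a saturated carbon. Going by the values given here, no measured pair shows this step, so its size is not known from the data. With one fewer such ester on the shared core, the number for compound 4 is expected to rise, and the step of a 2.2-fold higher number from compound 3 to compound 4 (0.35 log units; beyond the scatter) is expected to go beyond the scatter. Compound 4 is estimated at 45000 nM, with a range from 15000 nM to 130000 nM.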

Compound 4, half-maximal inhibitory concentration: 16600 nM
Beside the measured number, compound 4's estimate is 2.7-fold (0.43 log units) above it; the range from low to high includes it.
By their numbers in this assay, from the lowest: compounds 1, 4 and 3 (each within the scatter of the next); then compound 2.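

In this assay, hydrogen in place of (2-(3,4-dihydroxyphenyl)ethenyl)carbonyl on this oxygen on a saturated carbon gives a 1.2-fold lower number from compound 3 to compound 4 (0.09 log units; within the scatter). This step stays within the scatter, so on the shared core a number in this range does not depend on this ester, and the expected loss with one fewer ester does not appear. Nothing available accounts for this result.

Still open, from the compounds shown here alone, is whether a smaller ester such as acetyl, or an amine, at this place would separate from compound 4 in this assay. Also open, going by these compounds, is whether the number holds with hydrogen in place of the remaining ester.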